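A carbamate series: from acyloxyalkyl to trichloroethyl

A few compounds are considered here, and "the series" means these few. Any claim that something is new, unique, unknown or untested is made for them only; others in the source may bear on it.

This account follows compound 1 `CC(OC(=O)N1CCN(C(=O)c2nc(Nc3cc(C4CC4)[nH]n3)c3cc(Cl)ccc3n2)C[C@H]1C)OC(=O)C(C)(C)C` as it is changed into compound 3 `C[C@@H]1CN(C(=O)c2nc(Nc3cc(C4CC4)[nH]n3)c3cc(Cl)ccc3n2)CCN1C(=O)OCC(Cl)(Cl)Cl`. For the measured compounds named here, in an ADME assay on a cell-free system (plasma, Homo sapiens), read by HPLC, with a stated time of 120 min, at 37 degrees C (a higher number here means that more of the compound is left, a lower number that less of the compound is left), compound 1 gives 49.4%, the lower of the two numbers known so far; its nearest neighbour is compound 2 `CCCCCOC(=O)N1CCN(C(=O)c2nc(Nc3cc(C4CC4)[nH]n3)c3cc(Cl)ccc3n2)C[C@H]1C`, for which the same assay gives 74.4%. The difference between these two is a single step, pentyl in place of 1-(((tert-butyl)carbonyl)oxy)ethyl on an oxygen next to a carbonyl group, which produced a number 25 percentage points higher from compound 1 to compound 2 (beyond the scatter).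

The change to compound 3 is 2,2,2-trichloroethyl in place of 1-(((tert-butyl)carbonyl)oxy)ethyl on an oxygen next to a carbonyl group. Going by the values given here, it removes the same 1-(((tert-butyl)carbonyl)oxy)ethyl group that the step to compound 2 removed, so that step is the one piece of evidence that bears on it. On that basis compound 3 is expected to show a rise of similar size, a number 22.6 percentage points higher from compound 1 to compound 3 (beyond the scatter), with the estimate for compound 3 standing at 72% and a range of 52% to 92%.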

Compound 3, percent of the compound remaining: 79%
Compound 3: the middle estimate sits 7 percentage points below what was measured; measured number inside the range.
By their numbers in this assay, from the lowest: compound 1; then compounds 2 and 3 (each within the scatter of the next).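

In this assay, 2,2,2-trichloroethyl in place of 1-(((tert-butyl)carbonyl)oxy)ethyl on the oxygen next to a carbonyl group gives a number 29.6 percentage points higher from compound 1 to compound 3 (beyond the scatter), so the rise seen with pentyl is no longer tied to a single replacement. The two replacements themselves cannot be told apart, since trichloromethyl in place of butyl on the saturated chain carbon gives a number 4.6 percentage points higher from compound 2 to compound 3 (within the scatter), and at this position a chlorinated chain and a plain alkyl chain therefore stand level in this read-out. Nothing measured here explains either step.

As far as these compounds go, it remains open whether a shorter ethyl chain or a benzyl group on the same oxygen would stand level with compound 2 and compound 3. From the compounds shown here alone, with only compound 1 carrying an acyloxyalkyl group, it is also open whether a 1-(acetyloxy)ethyl group would stand level with compound 1.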